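Swapping a chlorophenyl for a trimethoxyphenyl on the shared core

The source may hold more compounds than are shown below. What is called first, only, known or untested is meant among the compounds shown, and "the series" means these compounds.

Of the compounds shown here, three have been tested in a functional assay on NCI-H460 cells (Homo sapiens) for inhibition; a higher number here means a weaker inhibitor of growth, a lower number a stronger inhibitor of growth. Compound 1 `COc1cc(/C=C/C(=O)c2cccc(-n3cc(-c4ccc(Cl)cc4)[nH]c3=O)c2)cc(OC)c1OC` gives 3740 nM; compound 2 `O=C(/C=C/c1cccc(O)c1)c1cccc(-n2cc(-c3ccccc3)[nH]c2=O)c1` gives 2490 nM; compound 3 `COc1ccc(-c2cn(-c3cccc(C(=O)/C=C/c4ccc(O)c(OC)c4)c3)c(=O)[nH]2)cc1` gives 3230 nM. Within the data shown here, these three numbers all lie within the usual scatter of one another, so no compound separates from the rest in this assay. Compound 4 `COc1cc(/C=C/C(=O)c2cccc(-n3cc(-c4cc(OC)c(OC)c(OC)c4)[nH]c3=O)c2)cc(OC)c1OC` has not yet been measured. It differs from compound 1 in one place: 3,4,5-trimethoxyphenyl in place of 4-chlorophenyl on an aromatic carbon. Among the measured compounds shown here, with no measured pair that shows this kind of swap, the expectation is a step from compound 1 to compound 4 of a 1.2-fold lower number from compound 1 to compound 4 (0.10 log units; within the scatter), that is, nothing beyond the scatter in either direction. Compound 4 is therefore estimated at 3000 nM in this assay, within a range from 1000 nM to 9000 nM.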

Compound 4, concentration for 50% growth inhibition: 1730 nM
Compound 4: middle estimate off by 1.7-fold (0.24 log units), on the high side, within the range that was stated.
By their numbers in this assay, from the lowest: compounds 4, 2, 3 and 1 (each within the scatter of the next, the first and the last beyond it).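

In this assay, the group on this aromatic carbon of the five-membered aromatic ring proves able to shift growth inhibition: 3,4,5-trimethoxyphenyl in place of 4-chlorophenyl gives a 2.2-fold lower number from compound 1 to compound 4 (0.33 log units; beyond the scatter) and so a stronger inhibitor, though the step is modest. The earlier compounds shown here differed in more than one place, so none of them could isolate a single change. No measurement at hand explains this step.

Still open, as far as these compounds go, is whether a group of another kind here, such as an amine or a carboxylic acid, would move the number further. Also open, from the compounds shown here alone, is whether the same swap gives a similar step when the rest of the molecule differs.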